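This account rests on a few compounds, and the source may have more. Where it says the series, first, only, none or still open, it means among the compounds named here.

Working notes on the series, measured in a functional assay on A549 cells (Homo sapiens) for cytotoxicity, read by MTT assay, with a stated time of 48 h; on this read-out higher numbers stand for weaker inhibition and lower numbers for stronger inhibition. Compound 1 `COc1c(OCc2nc3ccccc3[nH]2)cc(O)c2c(=O)cc(-c3ccccc3)oc12` gives > 100000 nM, which is a limit of the assay and not a number. Compound 3 `COc1c(OCCCNCc2ccccc2)cc(O)c2c(=O)cc(-c3ccccc3)oc12` has the lower of the two actual numbers, at 1570 nM, while compound 2 `COc1c(OCCCCNCc2ccccc2)cc(O)c2c(=O)cc(-c3ccccc3)oc12` gives 4590 nM.

The next comparison is compound 4 `COc1c(OCCCN2CCNCC2)cc(O)c2c(=O)cc(-c3ccccc3)oc12`, with piperazin-1-yl in place of benzylamino on a saturated chain carbon, three bonds along the chain from an oxygen on an aromatic ring. For the measured compounds named here, no measured step makes this exchange directly. The closest evidence is a 2.9-fold lower number from compound 2 to compound 3 (0.47 log units; beyond the scatter), with benzylamino in place of (benzylamino)methyl. The other two steps replace 1H-benzimidazol-2-yl and are much larger: an at least 21-fold lower number from compound 1 to compound 2 (1.33 log units; beyond the scatter) and an at least 63-fold lower number from compound 1 to compound 3 (1.80 log units; beyond the scatter). They show that changes at this end of the molecule can move the number substantially in this assay.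

A modest step towards a higher number is therefore expected, though a larger one remains possible, and the estimate is a 2.5-fold higher number from compound 3 to compound 4 (0.41 log units; beyond the scatter). For compound 4 the expected value is 4000 nM, within an estimated range of 1000 nM to 20000 nM.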

Compound 4, half-maximal inhibitory concentration: 10100 nM
Beside the measured number, compound 4's estimate is 2.5-fold (0.40 log units) below it, within the range that was stated.
By their numbers in this assay, from the lowest: compound 3; then compound 2; then compound 4. At a limit, above all of these: compound 1.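

In this assay, the exchange of benzylamino for piperazin-1-yl at this place gives a 6.4-fold higher number from compound 3 to compound 4 (0.81 log units; beyond the scatter), a larger move than the one between the two benzylamino chains, a 2.9-fold lower number from compound 2 to compound 3 (0.47 log units; beyond the scatter). The piperazin-1-yl group on the shorter chain also falls behind benzylamino on the longer chain, with a 2.2-fold higher number from compound 2 to compound 4 (0.34 log units; beyond the scatter), so in these compounds the identity of the amine outweighs that chain change. The piperazine still retains a clear margin over the benzimidazole, with an at least 9.9-fold lower number from compound 1 to compound 4 (0.99 log units; beyond the scatter), but this step rests on a limit for compound 1: the limit of > 100000 nM in this assay, at which 1 of the 4 values shown sits.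

The compounds shown do not separate the loss of the benzene ring from the change to a piperazine ring. A benzyl group on the piperazine, or a piperidine or morpholine on the same chain, would bear on that question.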